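The compounds below may be only part of what the source reports. "The series", "measured", "known", "first", "only" and "open" are said of these compounds alone.

Measured compounds:
compound 1 `COc1cc(/C=C2\CCC/C(=C\c3ccccc3[N+](=O)[O-])C2=O)cc(OC)c1OC` — 402 nM
compound 2 `Cc1ccc(/C=C2\CCC/C(=C\c3cccc([N+](=O)[O-])c3)C2=O)cc1` — 10100 nM
compound 3 `COc1ccc(/C=C2\CCC/C(=C\c3ccccc3[N+](=O)[O-])C2=O)cc1` — 7450 nM

In a functional assay on CCRF-CEM cells (Homo sapiens) for cytotoxicity, with a stated time of 72 h (on this read-out higher numbers stand for weaker inhibition and lower numbers for stronger inhibition), compound 2 gives the highest of the three numbers; compound 3 lies within the scatter of it, while compound 1 sits far lower, beyond the scatter. Compound 4 `O=C1/C(=C/c2ccccc2)CCC/C1=C\c1cccc([N+](=O)[O-])c1` is the phenyl analogue: hydrogen in place of methyl on an aromatic carbon. Cut one bond further out this reads 4-methylphenyl to phenyl. Among the measured compounds shown here, no measured pair isolates this change, so its effect is not known from the data. A methyl leaving for hydrogen on a carbon-only ring is a small change; no step beyond the scatter in this assay is expected in either direction. Compound 4 is therefore expected to give about 9000 nM, between 3000 nM and 30000 nM, the step meaning a 1.1-fold lower number from compound 2 to compound 4 (0.05 log units; within the scatter), which is an estimate only.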

Compound 4, half-maximal inhibitory concentration: 2290 nM
Compound 4: middle estimate off by 3.9-fold (0.59 log units), on the high side; measured number outside the range, below it.
By their numbers in this assay, from the lowest: compound 1; then compound 4; then compounds 3 and 2 (each within the scatter of the next).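

In this assay, among the compounds shown here, hydrogen in place of methyl on an aromatic carbon, para to a large group, gives a 4.4-fold lower number from compound 2 to compound 4 (0.64 log units; beyond the scatter) and is the first single-place step available. This position therefore responds to the loss of one carbon, and the phenyl compound is the stronger inhibitor of the pair. Nothing measured here explains the step.

From the compounds shown here alone, whether an ethyl group, a chlorine or an amine at this carbon would give a lower or higher number remains open. So does whether the same change would give a similar step on the core of compound 3.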